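This account rests on a few compounds, and the source may have more. Where it says the series, first, only, none or still open, it means among the compounds named here.

Measured compounds in an ADME assay on Vero cells (Chlorocebus sabaeus) for cytotoxicity, read by resazurin assay, with a stated time of 3 days; a higher number here means a weaker inhibitor, a lower number a stronger inhibitor:
- compound 1, `CCN(CC)c1cc2[nH]c(C3CCCCC3)nc2cc1NC(=O)c1ccc(F)cc1`: > 100 ug/mL, a limit of the assay, not a number
- compound 2, `Cc1ccc(C(=O)Nc2cc3nc(C4CCCCC4)[nH]c3cc2N2CCCC2)cc1`: > 100 ug/mL, likewise a limit of the assay
- compound 3, `CCc1ccc(C(=O)Nc2cc3nc(C4CCCCC4)[nH]c3cc2N(C)C)cc1`: > 100 ug/mL, likewise a limit of the assay

Compound 1 stands only at a limit in this assay. Within the data shown here, the same holds for compound 2 and for compound 3, so no order among the three can be read and no pair is separated beyond the scatter; this is summarised by the limit of > 100 ug/mL in this assay, at which 3 of the 3 values shown sit. Among the measured compounds shown here, no step between measured compounds is available, and nothing in the data points to a direction.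

Compound 4, `CCN(CC)c1cc2[nH]c(C3CCCCC3)nc2cc1NC(=O)OCCOCCOC`, is yet to be measured in this assay. It differs from compound 1 in one place: 2-(2-methoxyethoxy)ethoxy in place of 4-fluorophenyl on a carbonyl carbon. Because all values shown sit at the limit of > 100 ug/mL in this assay, at which 3 of the 3 values shown sit, the step expected in this assay from compound 1 to compound 4 is none beyond the scatter, in neither direction, and the most likely outcome is that the assay once more reports only its limit. Compound 4 is therefore estimated at 150 ug/mL in this assay, with a range from 50 ug/mL to 400 ug/mL. The step this estimate implies, a step that the limit leaves unreadable from compound 1 to compound 4, is expected to be flat.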

Compound 4, half-maximal inhibitory concentration: > 100 ug/mL
Compound 4 ended at the assay's limit; the forecaster's own chance of this, stated with the estimate: 80%; the middle value lies beyond the limit too.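

No step can be read from compound 1 to compound 4 in this assay because both compounds stand only at a limit of the assay, not at a number: the limit of > 100 ug/mL in this assay, at which 4 of the 4 values shown sit.

The compounds shown leave open how they rank against one another in this assay and whether 2-(2-methoxyethoxy)ethoxy in place of 4-fluorophenyl on a carbonyl carbon changes the read-out at all.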